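The source may hold more compounds than are shown below. What is called first, only, known or untested is meant among the compounds shown, and "the series" means these compounds.

Measured so far:
compound 1 `CCCCCCCCOc1nc(N)nc2c1ncn2/C=C1/CC1(CO)CO`: > 20000 nM
compound 2 `CC(C)CSc1nc(N)nc2c1ncn2/C=C1/CC1(CO)CO`: > 20000 nM

In an ADME assay on Akata cells (Homo sapiens) for cytotoxicity, with a stated time of 7 days (a higher number here means that more compound is tolerated, a lower number that less compound is tolerated), compound 1 reports only the assay limit, > 20000 nM. In this assay compound 2 also reports only the assay limit, > 20000 nM. The step that the two limits leave unreadable from compound 1 to compound 2 is therefore not readable; what the two measurements share is the limit of > 20000 nM in this assay, at which 2 of the 2 values shown sit. Compound 3 `CC(C)CNc1nc(N)nc2c1ncn2/C=C1/CC1(CO)CO` differs from compound 2 by isobutylamino in place of isobutylsulfanyl on an aromatic carbon. No readable measured step bears on this change, so no direction can be set from the data. Compound 3 is expected at 30000 nM, range 15000 nM to 100000 nM, most probably again reported as a limit. The expected step that the limit leaves unreadable from compound 2 to compound 3 is accordingly nominal only.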

Compound 3, half-maximal cytotoxic concentration: > 24000 nM
Compound 3 was reported as a limit; the forecaster's own chance of this, stated with the estimate: 85%; the middle value is on the limit's open side.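

In this assay, going by these compounds alone, compound 3 reports only a limit, > 24000 nM, so no step linking compound 1, compound 2 and compound 3 can be read. The compounds shown leave open what concentration of any of the three would be cytotoxic.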